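A Vinyl Group Replaces the Aryl Substituent

The compounds below may be only part of what the source reports. "The series", "measured", "known", "first", "only" and "open" are said of these compounds alone.

In a functional assay on KYSE-70 cells for antiproliferative activity against KYSE-70 cell line (Homo sapiens), read by MTT assay, with a stated time of 72 h (a higher number here means a weaker inhibitor, a lower number a stronger inhibitor), compound 1 `O=C(Nc1cccc(F)c1)c1cc(=O)[nH]c2cc(-c3ccc(F)cc3)ccc12` gives 3300 nM. Compound 2 `CC(=O)c1ccc(-c2ccc3c(C(=O)Nc4cccc(F)c4)cc(=O)[nH]c3c2)cc1` reaches only a limit of the assay, > 20000 nM. Compound 3 `O=C(Nc1cccc(F)c1)c1cc(=O)[nH]c2cc(-c3ccc(F)c(CO)c3)ccc12` also gives only a limit, > 20000 nM, and so stands at the limit of > 20000 nM in this assay, at which 2 of the 3 values shown sit. On these data alone, its true potency is therefore unknown, and the step to compound 2 stays open: a step that the two limits leave unreadable from compound 2 to compound 3.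

Compound 4 `C=Cc1ccc2c(C(=O)Nc3cccc(F)c3)cc(=O)[nH]c2c1` now takes the place of compound 3 in the comparison, with this change: vinyl in place of 4-fluoro-3-(hydroxymethyl)phenyl on an aromatic carbon. Among the compounds with values here, no measured compound lacks the aromatic ring on that carbon, so the evidence is indirect. Within the data shown here, two measured steps bear on the change. One is an at least 6.0-fold higher number from compound 1 to compound 2 (0.78 log units; beyond the scatter), and the other is an at least 6.0-fold higher number from compound 1 to compound 3 (0.78 log units; beyond the scatter). Both changes to the aromatic group of compound 1 moved this assay towards weaker inhibition, by at least a modest amount.

Removing that whole group could therefore lead away from the limit. Compound 1 at 3300 nM remains the only measured reference with a readable number. A modest step to a lower number is expected, although compound 4 may also reach the limit. The expected step is an at least 1.8-fold lower number from compound 3 to compound 4 (0.25 log units; that floor lies within the scatter). The estimate for compound 4 is 11000 nM, with an expected range from 3500 nM to 30000 nM.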

Compound 4, half-maximal inhibitory concentration: 9700 nM
The estimate for compound 4 lay 1.1-fold (0.05 log units) above the measured number, within the range that was stated.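

Vinyl, with no ring, brings the value back from the limit: it gives an at least 2.0-fold lower number from compound 3 to compound 4 (0.31 log units; beyond the scatter) and an at least 2.0-fold lower number from compound 2 to compound 4 (0.31 log units; beyond the scatter), so in this assay a readable value at this aromatic carbon does not depend on carrying an aromatic ring there. The ring still matters in one case, since the step that replaces 4-fluorophenyl with vinyl is a 2.9-fold higher number from compound 1 to compound 4 (0.47 log units; beyond the scatter), which leaves the 4-fluorophenyl group of compound 1 ahead of vinyl while the 4-acetylphenyl and 4-fluoro-3-(hydroxymethyl)phenyl groups fall behind it. The two steps from the limits give only floors, and the step between compound 2 and compound 3 cannot be read: the limit of > 20000 nM in this assay, at which 2 of the 4 values shown sit.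

Among the compounds shown, vinyl is the only group without a ring on this carbon, so it remains open whether the gain belongs to small groups in general or to vinyl alone. An ethyl group, a longer chain or an amine at this place could answer that, and unsubstituted phenyl could show how much of the value of compound 1 rests on its fluorine.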